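The source may report more compounds than this note shows. Statements on the series, on what has been measured and on what is new or still open speak of the compounds shown alone.

Measured compounds in a functional assay on the whole organism (Tail, strain ICR) with Mus musculus as the target, in the tail flick test, with a stated time of 60 min, at a dose of 25 umol/kg by the oral route; a higher number here means a stronger effect of the compound at the dose given, a lower number a weaker effect:
compound 1 `O=C(O)[C@@H]1CCCN1C(=O)CN(c1nc(Cl)nc2[nH]cnc12)C1CC1` — 34.9%
compound 2 `CC[C@H](C)[C@H](NC(=O)CN(c1nc(Cl)nc2[nH]cnc12)C1CC1)C(=O)O` — 36%
compound 3 `O=C(O)CC[C@H](NC(=O)CN(c1nc(Cl)nc2[nH]cnc12)C1CC1)C(=O)O` — 33.3%

All three compounds share the same core and differ only in the group on the saturated chain carbon bound to an amide-type nitrogen and a carbonyl carbon. Compound 3 stands lowest of the three numbers in this assay, but its nearest neighbour compound 1 and its furthest neighbour compound 2 both lie within the scatter of it, so no order among the three can be read from the values.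

Among the compounds with values here, the one single-point step among the measured compounds is a number 2.7 percentage points lower from compound 2 to compound 3 (within the scatter), a change from sec-butyl to 2-carboxyethyl that left the read-out within the scatter.

Compound 4 `CC(C)[C@H](NC(=O)CN(c1nc(Cl)nc2[nH]cnc12)C1CC1)C(=O)O` is not yet measured. It differs from compound 3 as follows: isopropyl in place of 2-carboxyethyl on a saturated chain carbon bound to an amide-type nitrogen and a carbonyl carbon. This runs the earlier step in the opposite sense, going from 2-carboxyethyl back to a branched alkyl, here isopropyl rather than sec-butyl. Since the step from compound 2 to compound 3 stayed within the scatter, the return in compound 4 is expected to do the same, with no step beyond the scatter in either direction.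

The expected step is a number 2.2 percentage points higher from compound 3 to compound 4 (within the scatter). Compound 4 is therefore estimated at 35.5%, in the range 25% to 46%.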

Compound 4, a percentage reported as activity, at one dose (the size of the read-out at that dose, not a potency): 38.8%
Compound 4: the middle estimate sits 3.3 percentage points below what was measured; the measured number falls inside the stated range.
By their numbers in this assay, from the lowest: compounds 3, 1, 2 and 4 (each within the scatter of the next).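

In this assay, isopropyl in place of 2-carboxyethyl on a saturated chain carbon bound to an amide-type nitrogen and a carbonyl carbon gives a number 5.5 percentage points higher from compound 3 to compound 4 (within the scatter), so a second branched alkyl group at this position also leaves the read-out within the scatter of the 2-carboxyethyl compound. The series now also covers hydrogen in place of methyl on a saturated chain carbon, three bonds along the chain from an amide-type nitrogen and a carbonyl carbon, with a number 2.8 percentage points higher from compound 2 to compound 4 (within the scatter), and (1-carboxy-2-methylpropyl)amino in place of 2-carboxypyrrolidin-1-yl on a carbonyl carbon, with a number 3.9 percentage points higher from compound 1 to compound 4 (within the scatter); neither of these changes gives a step beyond the scatter. No supporting data are available to account for the read-out at this position.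

Whether an amine, a phenyl ring or a plain hydrogen at this position would give a step beyond the scatter remains open, as no such group appears among these four compounds. On these data alone, with a read-out at one dose and one time only, how the four compare in potency also remains open.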